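A few compounds are considered here, and "the series" means these few. Any claim that something is new, unique, unknown or untested is made for them only; others in the source may bear on it.

Measured so far in a functional assay on ECa-109 cells for inhibition, with ECa-109 cell line (Homo sapiens) as the target, read by sulforhodamine B assay; a lower number here means a stronger inhibitor, a higher number a weaker inhibitor:
compound 1 `O=C1C(NC2CCCC2)=CC(=O)c2c1nc1n2[C@H]2OC[C@@H](O)[C@H]2OC1` gives > 16000 nM, which is a limit of the assay rather than a number (the limit of > 16000 nM in this assay, at which 1 of the 3 values shown sits).
compound 2 `O=C1C=C(Nc2ccccc2)C(=O)c2c1nc1n2[C@H]2OC[C@@H](O)[C@H]2OC1` gives 4970 nM.
compound 3 `O=C1C=C(Nc2cccc(Cl)c2)C(=O)c2c1nc1n2[C@H]2OC[C@@H](O)[C@H]2OC1` gives 4690 nM.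

Compound 1 thus stands only at a limit. Compound 2 and compound 3 both give numbers, and the step of a 1.1-fold lower number from compound 2 to compound 3 (0.03 log units; within the scatter) lies within the scatter. Compound 4 `O=C1C(Nc2cccc(F)c2)=CC(=O)c2c1nc1n2[C@H]2OC[C@@H](O)[C@H]2OC1` differs from compound 1 by 3-fluorophenyl in place of cyclopentyl on an amine nitrogen. Within the data shown here, no measured step covers this exchange directly. Compound 1 reaches only a limit; compound 2, which carries phenyl, gives a number. The step of a 1.1-fold lower number from compound 2 to compound 3 (0.03 log units; within the scatter) suggests a halogen on the ring changes little. Compound 4 is therefore expected to land among the aryl amines, meaning a step of an at least 3.3-fold lower number from compound 1 to compound 4 (0.52 log units; beyond the scatter). The estimate for compound 4 is 4800 nM, between 2000 nM and 12000 nM.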

Compound 4, half-maximal inhibitory concentration: 2370 nM
The estimate for compound 4 lay 2.0-fold (0.31 log units) above the measured number; measured number inside the range.
By their numbers in this assay, from the lowest: compounds 4, 3 and 2 (each within the scatter of the next, the first and the last beyond it). At a limit, above all of these: compound 1.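

Within a single exchange on this amine nitrogen, 3-fluorophenyl in place of cyclopentyl gives an at least 6.7-fold lower number from compound 1 to compound 4 (0.82 log units; beyond the scatter), the first step here that is beyond the scatter and the first to link an aromatic ring on this nitrogen to a lower number. Its true size stays open at the upper end, since compound 1 is a limit and not a number: the limit of > 16000 nM in this assay, at which 1 of the 4 values shown sits.

The compounds shown leave open whether the ring or its fluorine accounts for this step. They also leave open how a benzyl or cyclohexyl group on this nitrogen would read.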